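Pyrazolylamino pyrrolopyrimidines: N-methylation of the pyrazole

The compounds below may be only part of what the source reports. "The series", "measured", "known", "first", "only" and "open" are said of these compounds alone.

Measured so far in an assay on isolated protein for binding affinity to Leucine-rich repeat serine/threonine-protein kinase 2 variant G2019S (Homo sapiens), read by TR-FRET and LanthaScreen, with a stated time of 2 h; on this read-out higher numbers stand for weaker inhibition and lower numbers for stronger inhibition:
- compound 1 `Cc1c(Nc2nc(N)c3c(C#N)c(N4CCC[C@H]4C)n(C)c3n2)cnn1C`: 3 nM
- compound 2 `C[C@@H]1CCCN1c1c(C#N)c2c(N)nc(N)nc2n1C`: 13 nM
- compound 3 `Cc1n[nH]cc1Nc1nc(N)c2c(C#N)c(N3CCC[C@H]3C)n(C)c2n1`: 2 nM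

Compound 3 carries the lowest number of the three, but its gap to compound 1, a 1.5-fold lower number from compound 1 to compound 3 (0.18 log units; within the scatter), is within the scatter, so the two cannot be ordered. The substituent on the exocyclic amine itself matters: a 4.3-fold higher number from compound 1 to compound 2 (0.64 log units; beyond the scatter) and a 6.5-fold lower number from compound 2 to compound 3 (0.81 log units; beyond the scatter) are both beyond the scatter.

Compound 4 `Cc1nn(C)cc1Nc1nc(N)c2c(C#N)c(N3CCC[C@H]3C)n(C)c2n1` differs from compound 3 by methyl in place of hydrogen on an aromatic nitrogen. The step that bears most directly is the comparison of a methylated pyrazole nitrogen with a free one, compound 1 against compound 3, which was a 1.5-fold lower number from compound 1 to compound 3 (0.18 log units; within the scatter); the carbon-bound methyl also shifts between those two, so the comparison is not clean, but nothing in it points to a large effect of the nitrogen methyl. A step no larger than the scatter is therefore expected for a 1.5-fold higher number from compound 3 to compound 4 (0.18 log units; within the scatter), if anything toward a slightly higher number. Compound 4 is estimated at 3 nM in this assay, with a range of 1.5 nM to 7 nM.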

Compound 4, inhibition constant: 2 nM
The estimate for compound 4 lay 1.5-fold (0.18 log units) above the measured number, and the stated range covers the measured number.
By their numbers in this assay, from the lowest: compounds 3, 4 and 1 (each within the scatter of the next); then compound 2.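

In this assay, methyl in place of hydrogen on the aromatic nitrogen now stands as a single change, with no shift of the carbon-bound methyl (no change at the digits printed from compound 3 to compound 4 (within the scatter)), so this nitrogen accepts a methyl without a step beyond the scatter. Within the data shown here, the 1,3-dimethyl-1H-pyrazol-4-yl group keeps the advantage over the bare amine (a 6.5-fold lower number from compound 2 to compound 4 (0.81 log units; beyond the scatter)) and cannot be ordered against the 1,5-dimethyl-1H-pyrazol-4-yl group (a 1.5-fold lower number from compound 1 to compound 4 (0.18 log units; within the scatter)), so the place of the carbon-bound methyl shows no effect in this pair. No evidence at hand accounts for this tolerance.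

Going by these compounds, whether the same nitrogen takes an ethyl, a 2-hydroxyethyl chain or a piperidin-4-yl group remains open. On these data alone, with a single read-out, any difference between compound 3 and compound 4 outside this assay also remains open.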